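The source may report more compounds than this note shows. Statements on the series, on what has been measured and on what is new or still open speak of the compounds shown alone.

Measured in a functional assay on HFF cells (Homo sapiens) for cytotoxicity; a higher number here means a weaker inhibitor, a lower number a stronger inhibitor:
- compound 1 `Nc1nc2cc(Cl)c(Cl)cc2n1C1O[C@H](CO)[C@@H](O)[C@H]1O`: 32000 nM
- compound 2 `OC[C@H]1OC(n2c(I)nc3cc(Cl)c(Cl)cc32)[C@H](O)[C@@H]1O`: 127000 nM
- compound 3 `OC[C@H]1OC(n2c(O)nc3cc(Cl)c(Cl)cc32)[C@H](O)[C@@H]1O`: 100000 nM

Compound 3 stands high among these numbers. Its gaps to the others are a 1.3-fold lower number from compound 2 to compound 3 (0.10 log units; within the scatter) and a 3.1-fold higher number from compound 1 to compound 3 (0.49 log units; beyond the scatter).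

Compound 4 `Nc1c(Cl)c(Cl)cc2c1nc(O)n2C1O[C@H](CO)[C@@H](O)[C@H]1O` keeps the hydroxy group of compound 3 and changes the core: amino in place of hydrogen on an aromatic carbon. For the measured compounds named here, no measured step adds an amino group at this place. The nearest evidence is compound 1, whose amino group sits elsewhere: losing it gave a 4.0-fold higher number from compound 1 to compound 2 (0.60 log units; beyond the scatter) and a 3.1-fold higher number from compound 1 to compound 3 (0.49 log units; beyond the scatter). These modest steps bear only loosely, so a modest move to a lower number in this assay is expected. The expected step is a 1.7-fold lower number from compound 3 to compound 4 (0.22 log units; within the scatter). For compound 4 the estimated value is 60000 nM, with an expected range from 25000 nM to 130000 nM.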

Compound 4, half-maximal inhibitory concentration: > 100000 nM
Compound 4: a limit, no number (the forecaster's own chance of this, stated with the estimate: 20%); middle value at least 1.6-fold (0.22 log units) from the limit.
By their numbers in this assay, from the lowest: compound 1; then compounds 3 and 2 (each within the scatter of the next).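

In this assay compound 4 gives > 100000 nM which is a limit and not a number. Amino in place of hydrogen on this aromatic carbon, ortho to a chloro group, gives a number no lower from compound 3 to compound 4 (the limit leaves the size open) and so the lower number that went with the amino group of compound 1 (a 3.1-fold higher number from compound 1 to compound 3 (0.49 log units; beyond the scatter)) does not appear at this place. The reading for compound 4 sits at the limit of the assay: the limit of > 100000 nM in this assay, at which 1 of the 4 values shown sits. From the compounds shown here alone, how far compound 4 lies past that limit stays open, as does whether a methylamino group or a carboxylic acid on this carbon would lower the number.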